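The compounds below may be only part of what the source reports. "The series", "measured", "known", "first", "only" and "open" are said of these compounds alone.

Measured so far:
Compound 1, `O=C(Nc1ccc(Cl)c(-c2nnc3c(Cl)cccn23)c1)c1ccccc1Cl`; in a functional assay on A549 cells (Homo sapiens) for antiproliferative activity, read by MTT assay, with a stated time of 72 h (a lower number here means a stronger inhibitor, a higher number a weaker inhibitor), compound 1 gives > 100000 nM, which is a limit of the assay rather than a number.
Compound 2, `O=C(Nc1ccc(Cl)c(-c2nnc3c(Cl)cccn23)c1)c1ccc(Cl)cc1`; compound 2 gives 73600 nM.
Compound 3, `CS(=O)(=O)c1cccc(C(=O)Nc2ccc(Cl)c(-c3nnc4c(Cl)cccn34)c2)c1`; compound 3 gives > 100000 nM, again a limit of the assay and not a number.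

Compound 3 therefore stands at the edge of what this assay can report, and it is not alone there: the limit of > 100000 nM in this assay, at which 2 of the 3 values shown sit. Only compound 2 carries a true number, and the steps around it are small: an at least 1.3-fold lower number from compound 1 to compound 2 (0.13 log units; that floor lies within the scatter), an at least 1.3-fold higher number from compound 2 to compound 3 (0.13 log units; that floor lies within the scatter), while a step that the two limits leave unreadable from compound 1 to compound 3.

Compound 4, `CS(=O)(=O)c1ccc(C(=O)Nc2ccc(Cl)c(-c3nnc4c(Cl)cccn34)c2)cc1`, has not yet been measured. It differs from compound 3 in one place: 4-(methylsulfonyl)phenyl in place of 3-(methylsulfonyl)phenyl on a carbonyl carbon. The closest measured parallel is the move from 2-chlorophenyl to 4-chlorophenyl on the carbonyl carbon, a step whose floor lies within the scatter. Moving the methylsulfonyl group along the ring is therefore expected to change little, and because compound 3 already sits at > 100000 nM, any small change in this assay may again be hidden. Compound 4 is expected to give about 100000 nM in this assay, within 40000 nM to 250000 nM. The expected step is a number no higher from compound 3 to compound 4 (the limit leaves the size open).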

Compound 4, half-maximal inhibitory concentration: > 100000 nM
Compound 4 gave a limit, no number; the forecaster's own chance of this, stated with the estimate: 65%; the middle value lies on the limit itself.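

Compound 4 gives > 100000 nM in this assay, which is a limit of the assay and not a number, so the methylsulfonyl group now sits at this limit both as 3-(methylsulfonyl)phenyl and as 4-(methylsulfonyl)phenyl on the carbonyl carbon. Going by these compounds alone, the steps from compound 3 to compound 4 and from compound 1 to compound 4 cannot be read, with a limit at each end, while the one readable step is an at least 1.3-fold higher number from compound 2 to compound 4 (0.13 log units; that floor lies within the scatter), for methylsulfonyl in place of chloro on an aromatic carbon, and it gives only a floor, not a true size. Compound 2 is the one compound that goes against the pattern and carries a real number, and the rest of the series gathers at a single edge: the limit of > 100000 nM in this assay, at which 3 of the 4 values shown sit.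

Still open, on these data alone, is whether an amine or a carboxylic acid on this phenyl ring, or a longer chain on the carbonyl carbon in place of the ring, would give a clear number in this assay. Also open, as far as these compounds go, is whether compound 3 and compound 4 truly differ at all, as neither carries a number that could be compared.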